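The source may report more compounds than this note shows. Statements on the series, on what has been measured and on what is new or still open speak of the compounds shown alone.

Of the compounds shown here, three have so far been measured in a functional assay on HeLa cells for antagonist activity at 5-hydroxytryptamine receptor 6 (Homo sapiens); on this read-out higher numbers stand for weaker inhibition and lower numbers for stronger inhibition. Compound 1 `CC(C)n1nc(S(=O)(=O)c2cccc3ccccc23)c2cc(N3CCN(C)CC3)ccc21` gives 1.8 nM. Compound 3 `CN1CCN(c2cccc3c(S(=O)(=O)c4cccc5ccccc45)n[nH]c23)CC1` gives 17 nM. Compound 2 `Cc1ccc(S(=O)(=O)c2n[nH]c3ccc(N4CCN(C)CC4)cc23)cc1` gives 112 nM, the highest of the three numbers and so the weakest inhibition seen here; its gap to compound 3 is the smaller one and its gap to compound 1 the larger, and both gaps lie beyond the usual scatter of this assay.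

Compound 4 `COc1ccc(S(=O)(=O)c2n[nH]c3ccc(N4CCN(C)CC4)cc23)cc1` differs from compound 2 in one place only: methoxy in place of methyl on an aromatic carbon. For the measured compounds named here, no pair of measured compounds differs in a single spot, so there is no measured step of the same kind to compare with. The change is a small one, made at the outer end of the molecule, and the three measured compounds offer no direction for it. The step from compound 2 to compound 4 is therefore expected to be small, a 1.2-fold lower number from compound 2 to compound 4 (0.09 log units; within the scatter), and not clearly beyond the scatter in either direction. Compound 4 is thus estimated at 90 nM in this assay, with a plausible range from 30 nM to 300 nM.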

Compound 4, half-maximal inhibitory concentration: 544 nM
Estimate against measurement, compound 4: 6.0-fold (0.78 log units) below; measured number outside the range, above it.
By their numbers in this assay, from the lowest: compound 1; then compound 3; then compound 2; then compound 4.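

Going from 4-methylphenyl to 4-methoxyphenyl gives a 4.9-fold higher number from compound 2 to compound 4 (0.69 log units; beyond the scatter) in this assay, so a change of one methyl to one methoxy at this place is enough to weaken inhibition by more than the usual scatter. For the compounds shown here, the earlier compounds contained no pair differing in a single place, so this is the first direct sign that the group on this aromatic carbon matters, and that swapping it here can cost activity. Nothing available explains why the methoxy compound reads weaker than the methyl compound.

This single pair cannot separate the effect of the added oxygen from that of the larger group, and it gives no trend. The compounds shown leave open how an ethyl group, a hydroxyl group or a chlorine atom at this same place would compare.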